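Estimating Solubility for a Trifluoropropyl Ether

A few compounds are considered here, and "the series" means these few. Any claim that something is new, unique, unknown or untested is made for them only; others in the source may bear on it.

Measured so far in a physicochemical assay for solubility; on this read-out lower numbers stand for lower solubility and higher numbers for higher solubility:
Compound 1 `C[C@H](Oc1ccc(S(C)(=O)=O)cc1C(=O)N1Cc2ccc(C3CCOCC3)cc2C1)C(F)(F)F`: 76 ug/mL
Compound 2 `CC(C)Oc1ccc(S(C)(=O)=O)cc1C(=O)N1Cc2ccc(C3CCOCC3)cc2C1`: 191 ug/mL

Among the measured compounds shown here, of the two measured compounds, compound 2 stands higher at 191 ug/mL, and the only other one is compound 1 at 76 ug/mL. The next compound, compound 3 `CS(=O)(=O)c1ccc(OCCC(F)(F)F)c(C(=O)N2Cc3ccc(C4CCOCC4)cc3C2)c1`, keeps the shared core and has 3,3,3-trifluoropropyl in place of isopropyl on an oxygen on an aromatic ring.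

For the measured compounds named here, only one measured step bears on this change. It is a 2.5-fold higher number from compound 1 to compound 2 (0.40 log units; beyond the scatter), a modest step beyond the scatter, made by placing isopropyl where 1-(trifluoromethyl)ethyl stood on the same oxygen. Like 3,3,3-trifluoropropyl, the group on compound 1 is a fluorinated chain, and compound 1 has the lower number in this assay. Compound 3 is therefore expected to fall below compound 2 by a similar modest amount, though a single pair is thin support and the two fluorinated chains differ in shape. The expected step is a 2.4-fold lower number from compound 2 to compound 3 (0.38 log units; beyond the scatter). For compound 3 the estimated value is 80 ug/mL, with an expected range of 30 ug/mL to 190 ug/mL.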

Compound 3, solubility: 334 ug/mL
Compound 3: middle estimate off by 4.2-fold (0.62 log units), on the low side, and the stated range ends below it.
By their numbers in this assay, from the lowest: compound 1; then compounds 2 and 3 (each within the scatter of the next).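

The change from isopropyl to 3,3,3-trifluoropropyl on this oxygen gives a 1.7-fold higher number from compound 2 to compound 3 (0.24 log units; within the scatter), so in this assay compound 3 cannot be told apart from compound 2. The two fluorinated chains, by contrast, do not read alike at this position: 3,3,3-trifluoropropyl in place of 1-(trifluoromethyl)ethyl gives a 4.4-fold higher number from compound 1 to compound 3 (0.64 log units; beyond the scatter), which shows that a trifluoromethyl end on the chain does not by itself place a compound with compound 1. Nothing in the available data explains why these two chains part in this way.

The compounds shown leave open whether the gap between compound 1 and compound 3 follows the branched or the straight form of the chain, a question that a plain propyl group or a 2,2,2-trifluoroethyl group on the same oxygen would help to settle. They also leave open how far this position tolerates other kinds of group in this assay, such as a longer chain, an amine or a carboxylic acid carried on this oxygen.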